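A Selenium-Bearing Group Enters in Place of Methylsulfanyl

The compounds below may be only part of what the source reports. "The series", "measured", "known", "first", "only" and "open" are said of these compounds alone.

Compound 1 `CS/C(=N\C(=O)c1cc2ccccc2s1)NC(=O)c1cc2ccccc2s1`: 88200 nM
Compound 2 `O=C(/N=C(/NC(=O)c1cccs1)[Se]Cc1ccccc1)c1cccs1`: > 100000 nM, a limit of the assay
Compound 3 `CS/C(=N\C(=O)c1cccs1)NC(=O)c1cccs1`: > 100000 nM, a limit of the assay

In a functional assay on HT-29 cells (Homo sapiens) for cytotoxicity, read by MTT assay, with a stated time of 72 h (a higher number here means that more compound is tolerated, a lower number that less compound is tolerated), compound 1 is the only one of the three with a number. Compound 2 reaches only a limit of this assay. Compound 3 likewise reaches only a limit. The step that the two limits leave unreadable from compound 3 to compound 2 is a group of 8 heavy atoms (7 carbon, 1 selenium; one six-membered aromatic ring of carbon only) in place of a group of 2 heavy atoms (1 carbon, 1 sulfur; no ring), on a carbon with a double bond to nitrogen; because both ends sit at the limit of > 100000 nM in this assay, at which 2 of the 3 values shown sit, its size cannot be read. The difference between the cores of compound 1 and compound 3 is not broken down here. Compound 4 `O=C(/N=C(/NC(=O)c1cc2ccccc2s1)[Se]Cc1ccccc1)c1cc2ccccc2s1` carries the same change on the core of compound 1: a group of 8 heavy atoms (7 carbon, 1 selenium; one six-membered aromatic ring of carbon only) in place of a group of 2 heavy atoms (1 carbon, 1 sulfur; no ring), on a carbon with a double bond to nitrogen. Its step in this assay is expected to be a 1.0-fold higher number from compound 1 to compound 4 (0.01 log units; within the scatter), resting on compound 3 and compound 2 both lying at the limit of > 100000 nM in this assay, at which 2 of the 3 values shown sit, which leaves no readable shift. Compound 4 is estimated at 90000 nM, within 30000 nM to 300000 nM.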

Compound 4, concentration lethal to 50% of the cells: > 100000 nM
Compound 4: only a limit was reported (the forecaster's own chance of this, stated with the estimate: 50%); middle value at least 1.1-fold (0.04 log units) from the limit.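

In this assay, replacing methylsulfanyl with the selenium-bearing group on the core of compound 1 gives an at least 1.1-fold higher number from compound 1 to compound 4 (0.05 log units; that floor lies within the scatter). Compound 4 reaches only a limit, > 100000 nM. The change therefore shows no drop in the number on this core, but it does not show how large the step is or whether the two cores respond alike, and neither this step's true size nor the step from compound 3 to compound 2 can be read: the limit of > 100000 nM in this assay, at which 3 of the 4 values shown sit.

The compounds shown leave open how a group with a readable value would behave on either core. On these data alone, an amine or a carboxylic acid on that same carbon, in place of methylsulfanyl, remains untested here in this assay.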